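Replacing 3-(trifluoromethyl)phenyl in Compound 3

A few compounds are considered here, and "the series" means these few. Any claim that something is new, unique, unknown or untested is made for them only; others in the source may bear on it.

Of the compounds shown here, three have so far been read in a physicochemical assay for solubility, measured as kinetic solubility (on this read-out lower numbers stand for lower solubility and higher numbers for higher solubility), and they span a wide range. Compound 2 (`CNC(=O)c1cc(C(=O)N[C@H]2[C@@H]3COC[C@@H]32)cc2c1O[C@H](CF)[C@H]2c1ccccc1`) gives 206 ug/mL on this scale. Compound 1 (`CNC(=O)c1cc(C(=O)N[C@H]2CC[C@H](O)CC2)c([C@@H](C)c2cccc(F)c2)o1`) is reported only as a limit (>= 63 ug/mL). Compound 3 (`CNC(=O)c1cc(C(=O)N[C@H]2CC[C@H](O)CC2)n([C@@H](C)c2cccc(C(F)(F)F)c2)n1`) gives 7 ug/mL and so holds the lower of the two actual numbers, with compound 2 higher by a margin well beyond the usual scatter.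

The next compound to be read is compound 4 (`CNC(=O)c1cc(C(=O)N[C@H]2CC[C@H](O)CC2)n([C@@H](C)c2ccccc2Cl)n1`). It carries 2-chlorophenyl in place of 3-(trifluoromethyl)phenyl on a saturated chain carbon bound to an aromatic nitrogen and a saturated chain carbon. Within the data shown here, no pair of measured compounds differs in just one place, so there is no direct precedent for the size of this step.

An upward move is nevertheless expected because compound 3 at 7 ug/mL sits at the bottom of the numbers seen so far. What is expected is a 5.7-fold higher number from compound 3 to compound 4 (0.76 log units; beyond the scatter) which would lie beyond the scatter, although the low end of the estimate falls within it. Compound 4 is estimated at 40 ug/mL in this assay with an expected range from 12 ug/mL to 150 ug/mL on the same scale.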

Compound 4, solubility: >= 182 ug/mL
Compound 4: only a limit was reported (the forecaster's own chance of this, stated with the estimate: 15%); middle value at least 4.5-fold (0.65 log units) from the limit.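

At the position on a saturated chain carbon bound to an aromatic nitrogen and a saturated chain carbon, the aryl group alone proves able to shift the read-out in this assay: with the rest of the molecule unchanged, 2-chlorophenyl in place of 3-(trifluoromethyl)phenyl brings an at least 26-fold higher number from compound 3 to compound 4 (1.41 log units; beyond the scatter). Among these compounds, this is the first step in the set that differs in one place only, so the earlier compounds could give no measure of what a single change does here. The size of this step is only a floor, because the reading of compound 4 is a limit and not a number: the limit of >= 182 ug/mL in this assay, at which 1 of the 4 values shown sits.

The change replaces trifluoromethyl with chlorine and also moves the substituent to a different place on the ring, so the compounds shown do not separate the choice of substituent from its placement. They also leave open how a pyridine ring, or a phenyl ring carrying a methoxy group or an amine, would read on this same carbon, and with compound 4 at a limit, how far any such group would differ from 2-chlorophenyl.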